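A few compounds are considered here, and "the series" means these few. Any claim that something is new, unique, unknown or untested is made for them only; others in the source may bear on it.

Working notes on the series. Three compounds share one core, all tested in a functional assay on MCF7 cells (Homo sapiens) for antiproliferative activity, with a stated time of 48 h; on this read-out lower numbers stand for stronger inhibition and higher numbers for weaker inhibition. Compound 1 `CCCCC(O)c1cccc(NC(=O)NCCCCl)c1` sits at the limit of the assay, > 100000 nM being a limit and not a number. Compound 2 `CCCCC(O)c1cccc(NC(=O)NC(=O)CCl)c1` gives 5700 nM in this assay. For compound 3 `CCCCC(O)c1cccc(NC(=O)NC(=O)CC)c1` this assay likewise returns only a limit, > 100000 nM. Among the numbers shown compound 3 therefore stands at the same limit as compound 1, which is the limit of > 100000 nM in this assay, at which 2 of the 3 values shown sit. The measured steps: an at least 17-fold lower number from compound 1 to compound 2 (1.24 log units; beyond the scatter) and an at least 17-fold higher number from compound 2 to compound 3 (1.24 log units; beyond the scatter), whereas the step that the two limits leave unreadable from compound 1 to compound 3.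

Compound 4 `CCCCC(O)c1cccc(NC(=O)CCCl)c1` is next. The change from compound 3: 2-chloroethyl in place of propanoylamino on a carbonyl carbon. Compound 4 thus carries chlorine on a chain, but not on a saturated chain carbon bound to a carbonyl carbon, which is the feature whose exchange gave the step of an at least 17-fold higher number from compound 2 to compound 3 (1.24 log units; beyond the scatter). Compound 1, whose chlorine sits on 3-chloropropyl on an amide-type nitrogen, gives > 100000 nM. On that basis no step beyond the scatter is expected from compound 3 to compound 4, the estimated step being a number no higher from compound 3 to compound 4 (the limit leaves the size open). Compound 4 is expected near 100000 nM, within 30000 nM to 300000 nM, most likely again as a limit.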

Compound 4, half-maximal inhibitory concentration: > 100000 nM
Compound 4: no number, only a limit; the forecaster's own chance of this, stated with the estimate: 75%; the middle value sits exactly at the limit.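

In this assay compound 4 gives > 100000 nM, a limit and not a number, so its steps from compound 1 and from compound 3 cannot be read. Within the data shown here, the one readable step comes with 2-chloroethyl in place of ((chloromethyl)carbonyl)amino on a carbonyl carbon: an at least 17-fold higher number from compound 2 to compound 4 (1.24 log units; beyond the scatter). Chlorine on a chain alone gives no number in these compounds, with compound 1 and compound 4 both carrying it and only compound 2 reading out as a number: the limit of > 100000 nM in this assay, at which 3 of the 4 values shown sit.

On these data alone, it remains open whether bromo in place of chloro on the chain carbon bound to the carbonyl carbon would also give a number in the setting of compound 2. As far as these compounds go, it is equally open whether a longer chain carrying chlorine, or an amine at the chain end, would do so, and how far the compounds at the limit lie from it.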